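Methoxy for fluoro on the phenoxy ring of compound 3

This account rests on a few compounds, and the source may have more. Where it says the series, first, only, none or still open, it means among the compounds named here.

Of the compounds shown here, three of one core have been measured in a functional assay on cells (Lymphocyte, Homo sapiens); a higher number here means a weaker inhibitor, a lower number a stronger inhibitor. Compound 1 `COc1ccc(OCC(=O)N2CCN(c3nc(N)nc4sc(-c5ccc(F)cc5)nc34)CC2)cc1` gives 40 nM. Compound 2 `Nc1nc(N2CCN(C(=O)COc3ccc(Cl)cc3)CC2)c2nc(-c3cccnc3)sc2n1` gives 50 nM, and compound 3 `Nc1nc(N2CCN(C(=O)COc3ccc(F)cc3)CC2)c2nc(-c3cccnc3)sc2n1` gives 12 nM, the lowest of the three numbers, beyond the scatter from both others. Going by the values given here, the one single-point step so far is a 4.2-fold lower number from compound 2 to compound 3 (0.62 log units; beyond the scatter), which shows that the substituent on the phenoxy ring moves this assay.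

Compound 4 `COc1ccc(OCC(=O)N2CCN(c3nc(N)nc4sc(-c5cccnc5)nc34)CC2)cc1` differs from compound 3 in one place: methoxy in place of fluoro on an aromatic carbon. Among the compounds with values here, no measured step exchanges fluoro for methoxy directly. Compound 1 carries methoxy at this place, on a core with a different aryl group, and its value of 40 nM sits above that of compound 3. Taken with the sensitivity of this position seen in a 4.2-fold lower number from compound 2 to compound 3 (0.62 log units; beyond the scatter), a modest rise in this assay is expected for compound 4, so that a 2.5-fold higher number from compound 3 to compound 4 (0.40 log units; beyond the scatter) is the estimated step. Compound 4 is therefore expected to give 30 nM, within a range of 10 nM to 90 nM.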

Compound 4, half-maximal inhibitory concentration: 12 nM
For compound 4 the middle estimate is 2.5-fold (0.40 log units) above the measured one; measured number inside the range.
By their numbers in this assay, from the lowest: compounds 3 and 4 (each within the scatter of the next); then compounds 1 and 2 (each within the scatter of the next).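

In this assay, with pyridin-3-yl on the shared core, there is no change at the digits printed from compound 3 to compound 4 (within the scatter) for 4-methoxyphenoxy against 4-fluorophenoxy, and the chloro compound stands apart from both, with a 4.2-fold lower number from compound 2 to compound 3 (0.62 log units; beyond the scatter) and also a 4.2-fold lower number from compound 2 to compound 4 (0.62 log units; beyond the scatter) on the same core. The exchange of 4-fluorophenyl for pyridin-3-yl can now be read with 4-methoxyphenoxy held constant, and it gives a 3.3-fold lower number from compound 1 to compound 4 (0.52 log units; beyond the scatter) as a second place in the molecule that moves this number. No measurement at hand accounts for fluoro and methoxy matching while chloro does not.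

As far as these compounds go, whether this match extends to other groups stays open: an amine or a carboxylic acid on the phenoxy ring, or a longer alkoxy chain in place of methoxy, would test it. From the compounds shown here alone, the aryl exchange is read only with methoxy on the phenoxy ring, so its size with fluoro or chloro there remains unknown.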